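A few compounds are considered here, and "the series" means these few. Any claim that something is new, unique, unknown or untested is made for them only; others in the source may bear on it.

Measured so far:
compound 1 `COc1cc(-c2cc3nccc(-c4c[nH]c5ccccc45)n3n2)cc(OC)c1OC`: > 10000 nM
compound 2 `COc1cc(-c2ccnc3cc(-c4ccc(C)c(C)c4)nn23)cc(OC)c1OC`: 272 nM

Both compounds were tested in a functional assay on A549 cells (Homo sapiens) for inhibition, read by CCK-8 assay, with a stated time of 48 h; a lower number here means a stronger inhibitor, a higher number a weaker inhibitor. Compound 1 reaches only a limit of the assay, > 10000 nM, and gives no number. Within the data shown here, compound 2 gives 272 nM, the only actual number so far, so it cannot yet be ranked against a second measured value.

Next in line is compound 3 `COc1cc(-c2ccnc3cc(-c4cn(C)c5ccccc45)nn23)cc(OC)c1OC`, which keeps the core of compound 2 and differs in one place: 1-methyl-1H-indol-3-yl in place of 3,4-dimethylphenyl on an aromatic carbon. In words, 1-methyl-1H-indol-3-yl stands in place of 3,4-dimethylphenyl on an aromatic carbon.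

Among the measured compounds shown here, the series contains no measured step between two close analogues, so nothing calibrates the size of this change. The expectation in this assay is a moderate shift towards stronger inhibition, with a loss of activity not excluded, and the range is therefore kept wide on both sides. The estimated change is a 1.8-fold lower number from compound 2 to compound 3 (0.26 log units; within the scatter). For compound 3 the expected value is 150 nM, with an estimated range of 25 nM to 1500 nM.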

Compound 3, half-maximal inhibitory concentration: 1340 nM
For compound 3 the middle estimate is 8.9-fold (0.95 log units) below the measured one; the measured number falls inside the stated range.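

In this assay, the position on the five-membered aromatic ring with 2 nitrogen now has its first readable step: 1-methyl-1H-indol-3-yl in place of 3,4-dimethylphenyl gives a 4.9-fold higher number from compound 2 to compound 3 (0.69 log units; beyond the scatter), so this exchange loses activity rather than gaining it. The position therefore responds to the group it carries, and the two-ring group with its ring nitrogen does not match 3,4-dimethylphenyl, although compound 3 still gives a number and not a limit. Nothing at hand accounts for the size of this step.

On these data alone, the exchange alters the number of rings, the ring nitrogen and the methyl groups all at once, so it remains open which of these carries the loss. Also open, as far as these compounds go, is how this position treats a phenyl ring with one methyl, a methoxy group, a chlorine, an amine or a carboxylic acid, and whether the methyl on the indole nitrogen matters, which an unmethylated 1H-indol-3-yl on the core of compound 2 would show.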